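A few compounds are considered here, and "the series" means these few. Any claim that something is new, unique, unknown or untested is made for them only; others in the source may bear on it.

Among the compounds with values here, in an in vivo ADME assay on the whole organism (strain 129/SvEvBrd x C57BL/6) for pharmacokinetics, with Mus musculus as the target, at a dose of 1 mg/kg by the intravenous route (a lower number here means slower removal, a higher number faster removal of the compound), compound 1 (`CC(O)c1nc([C@@H](O)[C@H](O)[C@H](O)CO)c[nH]1`) gives 16.4 mL/min/kg and compound 2 (`OC[C@@H](O)[C@@H](O)[C@H](O)c1c[nH]c(-c2ncc[nH]2)n1`) gives 31.5 mL/min/kg, so compound 2 stands within the scatter of the only other measured compound. Compound 3 (`OC[C@@H](O)[C@@H](O)[C@H](O)c1c[nH]c(-c2cnccn2)n1`) carries pyrazin-2-yl in place of 1H-imidazol-2-yl on an aromatic carbon. Within the data shown here, the one measured step at this place is a 1.9-fold higher number from compound 1 to compound 2 (0.28 log units; within the scatter), with 1H-imidazol-2-yl in place of 1-hydroxyethyl. That single step gives no ground for expecting a shift beyond the scatter in this assay, and the expected step is a 1.1-fold lower number from compound 2 to compound 3 (0.05 log units; within the scatter). The estimate for compound 3 is 28 mL/min/kg, with an estimated range of 13 mL/min/kg to 60 mL/min/kg.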

Compound 3, clearance: 13.4 mL/min/kg
Beside the measured number, compound 3's estimate is 2.1-fold (0.32 log units) above it; the range from low to high includes it.
By their numbers in this assay, from the lowest: compounds 3, 1 and 2 (each within the scatter of the next, the first and the last beyond it).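

In this assay, within the data shown here, replacing 1H-imidazol-2-yl with pyrazin-2-yl at this position gives a 2.4-fold lower number from compound 2 to compound 3 (0.37 log units; beyond the scatter) and is the first step here beyond the scatter, so a change from one aromatic ring to another at this place can move the number. Set against 1-hydroxyethyl, pyrazin-2-yl shows a 1.2-fold lower number from compound 1 to compound 3 (0.09 log units; within the scatter) and so is not told apart from that group. Nothing measured here accounts for either step. Still open, on these data alone, is where an amine, a carboxylic acid or a pyridin-2-yl ring at this place would fall.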